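Fluoro in place of chloro: an expected half-life

A few compounds are considered here, and "the series" means these few. Any claim that something is new, unique, unknown or untested is made for them only; others in the source may bear on it.

Measured in an ADME assay on S9 fraction from liver (Homo sapiens) for metabolic stability, read by LC-MS, using NADPH, with a stated time of 60 min, tested at 1 uM; on this read-out higher numbers stand for a longer-lived compound and lower numbers for a shorter-lived compound:
Compound 1 `Cc1ccccc1N(C)C(=O)c1ccc(-c2ccc(OS(N)(=O)=O)cc2)o1`: 0.783 h
Compound 2 `Cc1ccccc1N(C)C(=O)c1ccc(-c2ccc(OS(N)(=O)=O)cc2Cl)o1`: 0.65 h

Going by the values given here, only two compounds have been measured, and their values lie within the scatter of each other, so compound 2 stands level with compound 1. Compound 3 `Cc1ccccc1N(C)C(=O)c1ccc(-c2ccc(OS(N)(=O)=O)cc2F)o1` has fluoro in place of chloro on an aromatic carbon. Among the compounds with values here, the one measured step that bears on this change is a 1.2-fold lower number from compound 1 to compound 2 (0.08 log units; within the scatter), chloro in place of hydrogen on an aromatic carbon. On that evidence, no shift beyond the scatter is expected in this assay. The expected step is a 1.1-fold higher number from compound 2 to compound 3 (0.03 log units; within the scatter). For compound 3 the estimated half-life is 0.7 h, with an expected range of 0.4 h to 1.2 h.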

Compound 3, half-life: 0.85 h
Compound 3: middle estimate off by 1.2-fold (0.08 log units), on the low side, within the range that was stated.
By their numbers in this assay, from the lowest: compounds 2, 1 and 3 (each within the scatter of the next).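

At this aromatic carbon, ortho to a large group and meta to a sulfamoyloxy group, this assay now covers a second halogen, and swapping chloro for fluoro leaves the half-life within the scatter (a 1.3-fold higher number from compound 2 to compound 3 (0.12 log units; within the scatter)). Fluoro in place of hydrogen does the same (a 1.1-fold higher number from compound 1 to compound 3 (0.04 log units; within the scatter)), so hydrogen, chloro and fluoro all read alike here. Nothing available accounts for this result. From the compounds shown here alone, whether methoxy, trifluoromethyl or an amine at this carbon would move the half-life beyond the scatter remains open.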